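Chain length on the side arm: compound 2 to compound 3

The source may report more compounds than this note shows. Statements on the series, on what has been measured and on what is new or still open speak of the compounds shown alone.

Measured so far:
- compound 1, `CC(CC(=N)S)N1N=C(c2ccccc2)CCC1=O`: 9.2%
- compound 2, `N=C(S)CCCCN1N=C(c2ccccc2)CCC1=O`: 50.2%

Two compounds carry numbers in a functional assay on the whole organism (stomach) for inhibition, with Rattus norvegicus as the target, at a dose of 100 mg/kg by the intraduodenal route; on this read-out lower numbers stand for less inhibition and higher numbers for more inhibition at the one dose given (going by the name of the read-out). Compound 2 stands highest of the two, and its nearest neighbour, compound 1, sits well below it, a gap beyond the usual scatter. Within the data shown here, no single-point step between these two is on record, so only the two numbers themselves can be compared: the longer unbranched side chain of compound 2 goes with much more inhibition than the shorter, branched arm of compound 1.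

Compound 3, `N=C(S)CCN1N=C(c2ccccc2)CCC1=O`, is not yet measured. It keeps the core of compound 2 and differs in one place: a group of 3 heavy atoms (1 carbon, 1 nitrogen, 1 sulfur; no ring) in place of a group of 5 heavy atoms (3 carbon, 1 nitrogen, 1 sulfur; no ring), on a saturated chain carbon, two bonds along the chain from an amide-type nitrogen in a ring

The change removes two saturated chain carbons from the arm that carries the sulfur-bearing group, making the side chain of compound 3 the shortest of the three. Compound 1, with its own short arm, gives 9.2%, while compound 2 gives 50.2%. On that basis a downward step is expected, of moderate size, a number 25.2 percentage points lower from compound 2 to compound 3 (beyond the scatter). For compound 3 in this assay the estimate is 25%, with a plausible range from 5% to 50%.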

Compound 3, a percentage reported as inhibition, in the whole organism at one dose (the size of the read-out at that dose, not a potency): 38.2%
Estimate against measurement, compound 3: 13.2 percentage points below, within the range that was stated.
By their numbers in this assay, from the lowest: compound 1; then compound 3; then compound 2.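

Shortening the arm, with a group of 3 heavy atoms (1 carbon, 1 nitrogen, 1 sulfur; no ring) in place of a group of 5 heavy atoms (3 carbon, 1 nitrogen, 1 sulfur; no ring), gives a number 12 percentage points lower from compound 2 to compound 3 (beyond the scatter) in this assay, so the longer arm adds to the read-out, but a sizeable part of the inhibition remains with the short arm. Hydrogen in place of methyl on a saturated chain carbon bound to an amide-type nitrogen in a ring and a saturated chain carbon gives a number 29 percentage points higher from compound 1 to compound 3 (beyond the scatter), which ties the low number of compound 1 to the methyl branch and not to a short arm alone. No measurement at hand accounts for either step.

As far as these compounds go, two chain lengths on an unbranched arm define no trend, so it remains open whether a longer chain than that of compound 2 would raise the number further or lower it. Also open, from the compounds shown here alone, are the result of an amine or a carboxylic acid in place of the sulfur-bearing end of the arm, and whether a methyl branch would have the same effect on the longer arm of compound 2.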